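The compounds below may be only part of what the source reports. "The series", "measured", "known", "first", "only" and "open" are said of these compounds alone.

Of the compounds shown here, three have so far been measured in an ADME assay on MT4 cells (Homo sapiens) for cytotoxicity, read by MTT assay, with a stated time of 5 days; on this read-out higher numbers stand for lower toxicity in this test and lower numbers for higher toxicity in this test. Compound 2 `Cc1ccc(Nc2cc(Oc3c(C)cc(C)cc3C)cc(=O)[nH]2)cc1` gives 37000 nM in this assay. Compound 1 `Cc1cc(C)c(Oc2cc(Nc3ccc([N+](=O)[O-])cc3)[nH]c(=O)c2)c(C)c1` differs from compound 2 by nitro in place of methyl on an aromatic carbon, and in this assay compound 1 gives 26000 nM. The step of a 1.4-fold lower number from compound 2 to compound 1 (0.15 log units; within the scatter) is the only measured instance of this change among the compounds shown. Compound 3 `COc1cc(Oc2c(C)cc(C)cc2C)cc(Nc2ccc(C)cc2)n1` carries a different core; how the cores of compound 3 and compound 2 differ is not broken down here. In this assay compound 3 gives 35000 nM, and this number lies within the usual scatter of the numbers of both compound 2 and compound 1.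

Compound 4 `COc1cc(Oc2c(C)cc(C)cc2C)cc(Nc2ccc([N+](=O)[O-])cc2)n1` has not yet been measured. It differs from compound 3 by nitro in place of methyl on an aromatic carbon, the same change that separates compound 1 from compound 2, and the place where the change is made reads the same in both cases. Among the compounds shown this change occurs twice in all. Because the earlier step of a 1.4-fold lower number from compound 2 to compound 1 (0.15 log units; within the scatter) was small, compound 4 is expected to show a step of a 1.3-fold lower number from compound 3 to compound 4 (0.13 log units; within the scatter) of like size, resting only on that one measured instance. On this basis compound 4 is estimated to give 26000 nM in this assay, with a likely range from 13000 nM to 52000 nM.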

Compound 4, half-maximal cytotoxic concentration: 7200 nM
Estimate against measurement, compound 4: 3.6-fold (0.56 log units) above; measured number outside the range, below it.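

In this assay, the exchange of methyl for nitro on an aromatic carbon gives a 4.9-fold lower number from compound 3 to compound 4 (0.69 log units; beyond the scatter), and this step does not match the one seen for the same change on the other core: the same change on two cores in this assay, a 1.4-fold lower number (0.15 log units; within the scatter) from compound 2 to compound 1 and a 4.9-fold lower number (0.69 log units; beyond the scatter) from compound 3 to compound 4, 3.4-fold (0.53 log units) apart, beyond the scatter of two such steps. For the compounds shown here, this shows that, in this series, the size of the step did not carry over from the core of compound 2 to the core of compound 3, even though the place of the change reads the same in both pairs, and that only the step on the core of compound 3 lies beyond the scatter. Going by these compounds alone, it does not show why the two cores part, and with only two pairs it gives no rule for what this change would do on any further core.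

The compounds shown hold only methyl and nitro at this place, so how an amine, a nitrile or a carboxylic acid there would read on either core remains open. Going by these compounds, it also remains open which feature of the core of compound 3 goes with the larger step, as the two cores are compared here only as wholes.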